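The source may hold more compounds than are shown below. What is called first, only, known or untested is meant among the compounds shown, and "the series" means these compounds.

Measured in a functional assay on HL-60 cells (Homo sapiens) for inhibition, read by resazurin assay, with a stated time of 72 h; on this read-out lower numbers stand for stronger inhibition and higher numbers for weaker inhibition:
- compound 1 `CCSc1ccc(C2C(O)C(=O)N2c2cc(OC)c(OC)c(OC)c2)cc1`: 16 nM
- compound 2 `COc1ccc(C2C(O)C(=O)N2c2cc(OC)c(OC)c(OC)c2)cc1O`: 5 nM
- compound 3 `CCOc1ccc(C2C(O)C(=O)N2c2cc(OC)c(OC)c(OC)c2)cc1`: 11 nM

The lowest number of the three belongs to compound 2. The gaps to the other two are modest: a 2.2-fold higher number from compound 2 to compound 3 (0.34 log units; beyond the scatter), and a 3.2-fold lower number from compound 1 to compound 2 (0.51 log units; beyond the scatter). The remaining pair shows a 1.5-fold lower number from compound 1 to compound 3 (0.16 log units; within the scatter).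

Compound 4 `COc1ccc(C2CC(=O)N2c2cc(OC)c(OC)c(OC)c2)cc1O` is reached by hydrogen in place of hydroxy on a saturated ring carbon. Among the measured compounds shown here, no measured step touches this carbon, since compound 1, compound 2 and compound 3 all carry the hydroxy, so the data hold no direct precedent. For the measured compounds named here, the only guide is the size of the steps elsewhere, the largest being a 3.2-fold lower number from compound 1 to compound 2 (0.51 log units; beyond the scatter). A modest rise in this assay is expected, since compound 2 at 5 nM already sits lowest, but the direction is uncertain. The expected step is a 2.8-fold higher number from compound 2 to compound 4 (0.45 log units; beyond the scatter). The estimate for compound 4 is 14 nM, with an expected range of 3 nM to 80 nM.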

Compound 4, half-maximal inhibitory concentration: 8 nM
Compound 4: middle estimate off by 1.8-fold (0.24 log units), on the high side; the range from low to high includes it.
By their numbers in this assay, from the lowest: compounds 2, 4, 3 and 1 (each within the scatter of the next, the first and the last beyond it).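

In this assay, among the compounds shown here, hydrogen in place of hydroxy on the saturated ring carbon of the four-membered ring gives a 1.6-fold higher number from compound 2 to compound 4 (0.20 log units; within the scatter), the first reading at this carbon. With the 3-hydroxy-4-methoxyphenyl group on the ring atom next to this carbon, the hydroxy is therefore not required for a low number in this assay, and this one pair shows no measurable penalty for its removal. Nothing at hand bears on the reason for this result.

The compounds shown pair the hydrogen at this carbon only with the 3-hydroxy-4-methoxyphenyl group, so it remains open whether the change is equally small with the 4-ethoxyphenyl or 4-(ethylsulfanyl)phenyl groups of compound 3 and compound 1. Also open, from the compounds shown here alone, is how a methoxy, an amine or a fluorine at this carbon would read.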